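The source may report more compounds than this note shows. Statements on the series, on what has been measured and on what is new or still open speak of the compounds shown alone.

The three measured compounds:
- compound 1, `O=C1CC(c2c[nH]c3cc(Cl)ccc23)C(=O)N1`, gives 2100 nM in an assay on isolated protein for inhibition of Indoleamine 2,3-dioxygenase 1 (Homo sapiens), with a stated time of 15 min; a lower number here means a stronger inhibitor, a higher number a weaker inhibitor
- compound 2, `O=C1CC(c2c[nH]c3cc(F)c(F)cc23)C(=O)N1`, gives 1800 nM in this assay
- compound 3, `O=C1CC(c2cccc3cc(F)ccc23)C(=O)N1`, gives 1700 nM in this assay

Compound 3 has the lowest of the three numbers, yet its gaps to compound 2 and to compound 1 both lie within the usual scatter of repeated measurements, so the three cannot be ranked against each other. Compound 4, `O=C1CC(c2cccc3cc(Cl)ccc23)C(=O)N1`, differs from compound 3 in one place: chloro in place of fluoro on an aromatic carbon of a six-membered aromatic ring of carbon only, part of a fused system of two rings. Going by the values given here, no pair among the measured compounds differs in just this way, so there is no direct step to lean on. Compound 1, bearing chloro on its core, and compound 2, bearing fluoro groups on the same core, give numbers within the scatter of each other, and that comparison offers no basis for expecting a large step. The step from compound 3 to compound 4 is therefore expected to be small, a 1.1-fold lower number from compound 3 to compound 4 (0.05 log units; within the scatter), with no direction beyond the scatter. Compound 4 is estimated at 1500 nM, within a range from 700 nM to 3500 nM.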

Compound 4, half-maximal inhibitory concentration: > 50000 nM
Compound 4: only a limit was reported; the forecaster's own chance of this, stated with the estimate: 3%; middle value at least 33-fold (1.52 log units) from the limit.
By their numbers in this assay, from the lowest: compounds 3, 2 and 1 (each within the scatter of the next). At a limit, above all of these: compound 4.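

In this assay, putting chloro in place of fluoro on this one aromatic carbon gives an at least 29-fold higher number from compound 3 to compound 4 (1.46 log units; beyond the scatter), so a swap of a single atom at this position is far from neutral. Going by these compounds alone, none of the earlier compounds showed a difference beyond the scatter, which makes this the first sign that the series is sensitive to what sits on this ring carbon. The number for compound 4 is a limit of the assay and not a measured value, so the full size of the step stays unknown: the limit of > 50000 nM in this assay, at which 1 of the 4 values shown sits.

The compounds shown cannot tell why fluoro and chloro part so sharply here. As far as these compounds go, whether a methyl or a methoxy group on this carbon would stay close to compound 3 or end at a limit like compound 4 remains open.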